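Replacing the outer benzyloxy of compound 1 with methoxycarbonyl

The compounds below may be only part of what the source reports. "The series", "measured", "known", "first", "only" and "open" are said of these compounds alone.

Measured in a functional assay on SK-OV-3 cells (Homo sapiens) for inhibition, read by CCK-8 assay, with a stated time of 70 h; on this read-out higher numbers stand for weaker inhibition and lower numbers for stronger inhibition:
- compound 1 `c1ccc(COc2ccc(COc3ccc(OCCOCCNC4CCCCC4)cc3)cc2)cc1` gives 8080 nM
- compound 2 `c1ccc(COc2ccc(COc3ccc(OCCOCCNC4CCCC4)cc3)cc2)cc1` gives 10000 nM
- compound 3 `c1ccc(COc2ccccc2OCCOCCNC2CCCC2)cc1` gives 40700 nM

In this assay, compound 1 at 8080 nM lies within the scatter of compound 2, and compound 3 gives a higher number than both. The next compound is compound 4 `COC(=O)c1ccc(COc2ccc(OCCOCCNC3CCCCC3)cc2)cc1`, reached from compound 1 by this change: methoxycarbonyl in place of benzyloxy on an aromatic carbon. In words, it is methoxycarbonyl in place of benzyloxy on an aromatic carbon, para to a large group.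

Among the measured compounds shown here, the only measured step between single-site neighbours is a 1.2-fold higher number from compound 1 to compound 2 (0.09 log units; within the scatter). It lies within the scatter and concerns the amine nitrogen, so it says nothing direct about the site changed here. For the measured compounds named here, no measured step covers that site. The nearest hint is compound 3 at 40700 nM, which is smaller than compound 1 but differs from it in more than one place, so it gives direction only loosely. A move towards weaker inhibition is therefore expected, of moderate size and with wide uncertainty.

The expected step is a 2.5-fold higher number from compound 1 to compound 4 (0.39 log units; beyond the scatter). The estimated value for compound 4 is 20000 nM, with an expected range from 9000 nM to 45000 nM.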

Compound 4, half-maximal inhibitory concentration: 6220 nM
Compound 4: the middle estimate sits 3.2-fold (0.51 log units) above what was measured, and the stated range ends above it.
By their numbers in this assay, from the lowest: compounds 4, 1 and 2 (each within the scatter of the next); then compound 3.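

In this assay, methoxycarbonyl in place of benzyloxy gives a 1.3-fold lower number from compound 1 to compound 4 (0.11 log units; within the scatter). Among the compounds shown here, this is the first direct reading at this site, on an aromatic carbon para to a large group, and it shows that, for this pair, a group of 4 heavy atoms with no ring can stand in for one of 8 heavy atoms carrying a six-membered aromatic ring without a shift beyond the scatter, so the outer aromatic ring of benzyloxy is not needed to keep the number of compound 1 in this assay. No available evidence bears on why the two groups read alike.

On these data alone, two groups at one site make no trend, so it remains open whether other groups placed there, such as a carboxylic acid, a primary amide, an amine or a longer alkyl ester, would also stay within the scatter of compound 4. Also open, as far as these compounds go, is whether methoxycarbonyl reads the same when cyclopentyl replaces cyclohexyl on the amine nitrogen, and whether the series can reach numbers clearly lower than those of compound 4 and compound 1.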